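The compounds below may be only part of what the source reports. "The series", "measured", "known", "first", "only" and "open" are said of these compounds alone.

Measured in an ADME assay on microsomes from liver (Rattus norvegicus) for metabolic stability; on this read-out lower numbers stand for slow clearance and higher numbers for fast clearance:
Compound 1 `CNc1nc(NC2(C#N)CCCCC2)nc(-n2cccn2)n1`: 103 mL/min/kg
Compound 2 `CNc1nc(NC2(C#N)CCCCC2)nc(-n2cncn2)n1`: 52 mL/min/kg

Compound 2 shares its core with compound 1, and their two values lie within the scatter of each other, so the pair cannot be ranked. Compound 3 `CNc1nc(NC2(C#N)CCCCC2)nc(-n2ccnc2)n1` has not been measured and alters a single group of compound 2: 1H-imidazol-1-yl in place of 1H-1,2,4-triazol-1-yl on an aromatic carbon. The group stands on an aromatic carbon, opposite the ring nitrogen. For the measured compounds named here, the only measured step that bears on this is a 2.0-fold lower number from compound 1 to compound 2 (0.30 log units; within the scatter). It exchanges one five-membered aromatic ring for another at the same place and stays within the scatter. Going by the values given here, no measured compound other than compound 3's neighbours informs this change, and the 1H-imidazol-1-yl group itself is untested, so no shift beyond the scatter is expected. The expected step is a 1.4-fold higher number from compound 2 to compound 3 (0.16 log units; within the scatter). For compound 3 the estimated clearance is 75 mL/min/kg, with an expected range from 35 mL/min/kg to 150 mL/min/kg.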

Compound 3, clearance: 52 mL/min/kg
Estimate against measurement, compound 3: 1.4-fold (0.16 log units) above, and the stated range covers the measured number.
By their numbers in this assay, from the lowest: compounds 2, 3 and 1 (each within the scatter of the next).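

In this assay, exchanging the 1H-1,2,4-triazol-1-yl group for 1H-imidazol-1-yl on the aromatic carbon opposite the ring nitrogen gives no change at the digits printed from compound 2 to compound 3 (within the scatter), so having one ring nitrogen fewer in this group leaves no visible mark on the read-out. Exchanging the 1H-pyrazol-1-yl group for the same 1H-imidazol-1-yl gives a 2.0-fold lower number from compound 1 to compound 3 (0.30 log units; within the scatter), which means that none of the three five-membered aromatic rings can be ranked against the others at this position. Nothing measured here offers an explanation for these results.

On these data alone, it remains open whether a group of another kind at this position, such as a simple amine, a phenyl ring or a morpholine, would shift clearance beyond the scatter. As far as these compounds go, the effect of changing the methylamino group also remains unknown.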